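The compounds below may be only part of what the source reports. "The series", "measured", "known", "first", "only" and "open" are said of these compounds alone.

Measured compounds:
compound 1, `CC(C)c1cccc(OCC(=O)Nc2ccc(OCC(=O)O)c(F)c2)c1`; in a functional assay on CHO cells for agonist activity at Free fatty acid receptor 1 (Homo sapiens), read by FLIPR, tested at 100 nM (a higher number here means a stronger effect of the compound at the concentration tested, a lower number a weaker effect), compound 1 gives 43.3%.
compound 2, `COc1cccc(OCC(=O)Nc2ccc(OCC(=O)O)c(F)c2)c1`; in this assay compound 2 gives 31.7%.

Compound 2 stands lowest of the two numbers: the step of a number 11.6 percentage points lower from compound 1 to compound 2 (beyond the scatter) is beyond the scatter and modest in size. Compound 3, `O=C(O)COc1ccc(NC(=O)COc2cccc(C(F)(F)F)c2)cc1F`, is not yet measured. It differs from compound 2 by trifluoromethyl in place of methoxy on an aromatic carbon. For the measured compounds named here, the only measured step, a number 11.6 percentage points lower from compound 1 to compound 2 (beyond the scatter), concerns the same aromatic carbon, but there methoxy replaces isopropyl; neither measured compound carries trifluoromethyl, so no measured step involves the entering group. A change of about the size of the measured step in either direction, or none beyond the scatter, is all consistent with what is known. The expected step of a number 5.3 percentage points higher from compound 2 to compound 3 (within the scatter) is therefore set small, with wide uncertainty. For compound 3 the estimate in this assay is 37%, with a range of 20% to 55%.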

Compound 3, a percentage reported as activity, at one concentration (the size of the read-out at that concentration, not a potency): 11.4%
Compound 3: middle estimate off by 25.6 percentage points, on the high side, and the stated range ends above it.
By their numbers in this assay, from the lowest: compound 3; then compound 2; then compound 1.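

In this assay the group on this aromatic carbon matters more than the first pair could show: a number 20.3 percentage points lower from compound 2 to compound 3 (beyond the scatter), and a number 31.9 percentage points lower from compound 1 to compound 3 (beyond the scatter). For the compounds shown here, the second of these steps is large, whereas the only earlier step was modest, so the read-out at this position covers a wider span than compound 1 and compound 2 alone revealed, with trifluoromethyl giving the lowest number of the three. No available data bear on why trifluoromethyl sits lowest here.

Open, on these data alone, is where other groups on this carbon would fall, for example an amine, a nitrile, a chlorine atom or a longer alkyl chain, and whether any would exceed isopropyl. As far as these compounds go, these read-outs show the size of the effect at a single concentration only, so how strong the effect of each of the three compounds would be at other concentrations remains open.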